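Epimer at the benzylic methoxy carbon of compound 1

The source may hold more compounds than are shown below. What is called first, only, known or untested is meant among the compounds shown, and "the series" means these compounds.

Compound 1 `CO[C@@H]1[C@H]2OC(=O)C[C@H]2O[C@@H]1[C@@H](OC)c1ccccc1` gives 25100 nM in a functional assay on A549 cells (Homo sapiens) for inhibition, read by MTT assay, with a stated time of 72 h (on this read-out lower numbers stand for stronger inhibition and higher numbers for weaker inhibition), and stands with the highest number of the two measured compounds. Going by the values given here, its nearest neighbour is compound 2 `CO[C@@H](c1ccccc1)[C@H]1O[C@@H]2CC(=O)O[C@@H]2[C@H]1O`, which in this assay gives 5310 nM; the one measured step, a 4.7-fold lower number from compound 1 to compound 2 (0.67 log units; beyond the scatter), is a hydrogen in place of methyl on an oxygen on a saturated carbon. Compound 3 `CO[C@@H]1[C@H]2OC(=O)C[C@H]2O[C@@H]1[C@H](OC)c1ccccc1` is the unmeasured compound. It differs from compound 1 as follows: the two compounds have the same atoms and bonds and differ only in configuration as drawn: 1 of 5 stereo elements differ; a stereocentre at a saturated chain carbon is drawn S in compound 1 and R in compound 3. Among the compounds with values here, no measured step in this set changes configuration; the step from compound 1 to compound 2 alters a group and therefore does not bear on the move to compound 3. The expectation for compound 3 rests on compound 1 alone, with a wide range, and the expected step of a 1.0-fold lower number from compound 1 to compound 3 (0.00 log units; within the scatter) is not taken to lie beyond the scatter in either direction. Compound 3 is therefore estimated at 25000 nM in this assay, with a range from 7000 nM to 90000 nM.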

Compound 3, half-maximal inhibitory concentration: 26300 nM
Compound 3: middle estimate off by 1.1-fold (0.02 log units), on the low side; the range from low to high includes it.
By their numbers in this assay, from the lowest: compound 2; then compounds 1 and 3 (each within the scatter of the next).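

Going by these compounds alone, the new step, a 1.0-fold higher number from compound 1 to compound 3 (0.02 log units; within the scatter), is the first in this set to concern configuration, and in this assay it shows that the S drawing in compound 1 and the R drawing in compound 3 at this stereocentre at a saturated chain carbon cannot be told apart. The step can be read as bearing on that stereocentre alone because nothing else separates the pair: the fact that compounds 1 and 3 differ only in the configuration as drawn. Of the two steps now available, only a 4.7-fold lower number from compound 1 to compound 2 (0.67 log units; beyond the scatter) lies beyond the scatter, and it involves hydrogen in place of methyl on an oxygen on a saturated carbon rather than any difference in configuration.

From the compounds shown here alone, this reading holds only for the pair with the methyl on oxygen in both compounds, so it remains open whether configuration at this carbon would also make no visible difference in a compound carrying the hydrogen of compound 2. Going by these compounds, it also remains open whether that would hold with an amine or a longer chain in place of the methyl-bearing oxygen on this stereocentre.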